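Replacing allyl in compound 3 with an ester-bearing group

A few compounds are considered here, and "the series" means these few. Any claim that something is new, unique, unknown or untested is made for them only; others in the source may bear on it.

In a functional assay on A2780 cells (Homo sapiens) for antiproliferative activity, read by sulforhodamine B assay, with a stated time of 48 h (a higher number here means a weaker inhibitor of growth, a lower number a stronger inhibitor of growth), three compounds have been measured. Compound 1 `CC(C)(C)[Si](C)(C)O[C@H]1CCCO[C@@H]1COCC(=O)OCc1ccccc1` gives 36000 nM, compound 2 `CC(C)(C)[Si](C)(C)O[C@@H]1CCCO[C@@H]1COCC(=O)OCc1ccccc1` gives 81000 nM, and compound 3 `C=CCOC[C@H]1OCCC[C@H]1O[Si](C)(C)C(C)(C)C` gives 32000 nM. Compound 3 stands level with compound 1 within the scatter, while its number lies below that of compound 2 by more than the scatter.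

Compound 4 `COC(=O)/C=C/OC[C@H]1OCCC[C@H]1O[Si](C)(C)C(C)(C)C` has not yet been measured. The change leading to it is 2-(methoxycarbonyl)ethenyl in place of allyl on an oxygen on a saturated carbon, with 2-(methoxycarbonyl)ethenyl in place of allyl on an oxygen on a saturated carbon. Going by the values given here, only one measured step exists, a 2.3-fold higher number from compound 1 to compound 2 (0.35 log units; beyond the scatter), and it bears on this change only loosely because of the fact that compounds 1 and 2 differ only in the configuration as drawn. Among the compounds with values here, no measured step exchanges the group on that oxygen, so the direction of any change remains open. The measured step is modest, and the values stay in a narrow band, with compound 3 at 32000 nM and compound 2 at 81000 nM. A step beyond the scatter is therefore not expected, and the estimated change is a 1.3-fold higher number from compound 3 to compound 4 (0.10 log units; within the scatter). For compound 4 the expected value is 40000 nM, with an estimated range from 18000 nM to 90000 nM.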

Compound 4, concentration for total growth inhibition: 82000 nM
Beside the measured number, compound 4's estimate is 2.1-fold (0.31 log units) below it; low and high end bracket the measured number.
By their numbers in this assay, from the lowest: compounds 3 and 1 (each within the scatter of the next); then compounds 2 and 4 (each within the scatter of the next).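

In this assay, going by these compounds alone, this is the only measured step that exchanges the group on this oxygen on a saturated carbon, and it points upward: a 2.6-fold higher number from compound 3 to compound 4 (0.41 log units; beyond the scatter). Within the data shown here, the direction left open by the earlier compounds is thus settled for this one pair: 2-(methoxycarbonyl)ethenyl in place of allyl gives a weaker inhibitor of growth, by a modest step that lies beyond the scatter. The information at hand offers no explanation for this step.

The compounds shown leave open whether the step follows the methyl ester, the added double bond or the larger group as a whole; a carboxylic acid, an amide or a saturated chain ending in the same ester on this oxygen would be needed to separate these readings. They also leave open whether the same exchange gives a step of similar size and direction when the shared core carries the other configuration as drawn, or when a small amine-bearing chain stands on this oxygen instead.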